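A few compounds are considered here, and "the series" means these few. Any claim that something is new, unique, unknown or untested is made for them only; others in the source may bear on it.

Compound 1 `CN(C)c1ccc(/C=C2/S/C(=N\c3nc4cc(-c5ccc(Cl)cc5)sc4s3)NC2=O)cc1` | > 50000 nM
Compound 2 `O=C1N/C(=N/c2nc3cc(-c4ccc(Cl)cc4)sc3s2)S/C1=C/c1ccc(F)cc1` | > 50000 nM

In a functional assay on HT-29 cells (Homo sapiens) for inhibition, read by MTT assay, with a stated time of 72 h (a higher number here means a weaker inhibitor, a lower number a stronger inhibitor), compound 2 gives > 50000 nM, which is a limit of the assay and not a number. Compound 1 also gives only a limit, > 50000 nM. Together they show (the limit of > 50000 nM in this assay, at which 2 of the 2 values shown sit). Compound 3 `Cc1ccc(/C=C2/S/C(=N\c3nc4cc(-c5ccc(Cl)cc5)sc4s3)NC2=O)cc1` differs from compound 2 at one spot: methyl in place of fluoro on an aromatic carbon, para to a large group. Among the measured compounds shown here, the one measured step that bears on this change is a step that the two limits leave unreadable from compound 1 to compound 2. It alters the same aromatic carbon, but with limits at both ends its size cannot be read. No step beyond the scatter is therefore expected, and compound 3 will probably also stop at the limit. The expected change is a number no higher from compound 2 to compound 3 (the limit leaves the size open). For compound 3 the estimated value is 50000 nM, with an expected range from 15000 nM to 100000 nM.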

Compound 3, half-maximal inhibitory concentration: 45500 nM
The estimate for compound 3 lay 1.1-fold (0.04 log units) above the measured number; low and high end bracket the measured number.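

In this assay, among the compounds shown here, compound 3 gives 45500 nM, the only actual number among the three compounds, so a group at this place on the ring can now be read on the scale. The change to methyl gives an at least 1.0-fold lower number from compound 2 to compound 3 (0.04 log units; that floor lies within the scatter), and the same place gives an at least 1.0-fold lower number from compound 1 to compound 3 (0.04 log units; that floor lies within the scatter); both are floors, so the true steps may be larger, but neither is shown to exceed the scatter. Compound 1 and compound 2 each stop at a limit of the assay, not a number: the limit of > 50000 nM in this assay, at which 2 of the 3 values shown sit.

The compounds shown leave open how a methoxy group, a carboxylic acid or a longer alkyl chain would read at this place on the ring. They also leave open whether a change elsewhere on the shared core would move the number well clear of the limit.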